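Anilide variations of a sulfonylproline amide: cytotoxicity

The source may hold more compounds than are shown below. What is called first, only, known or untested is meant among the compounds shown, and "the series" means these compounds.

Compound 1 `O=C(Nc1ccccc1)[C@@H]1CCCN1S(=O)(=O)c1cccc2cccnc12` carries a plain phenyl on the amide nitrogen, and in an ADME assay on HEp-2 cells (Homo sapiens) for cytotoxicity (on this read-out higher numbers stand for lower toxicity in this test and lower numbers for higher toxicity in this test), compound 1 gives 35600 nM. Compound 2 `CCc1ccccc1NC(=O)[C@@H]1CCCN1S(=O)(=O)c1cccc2cccnc12` adds an ethyl, and in this assay compound 2 reaches only the assay limit of > 50000 nM. Compound 3 `Cc1ccnc(C)c1NC(=O)[C@@H]1CCCN1S(=O)(=O)c1cccc2cccnc12` likewise sits at the limit, > 50000 nM in this assay. Compound 2 thus stands at the limit of > 50000 nM in this assay, at which 2 of the 3 values shown sit. Within the data shown here, the step of an at least 1.4-fold higher number from compound 1 to compound 2 (0.14 log units; that floor lies within the scatter) is the only readable step ending at compound 2, while a step that the two limits leave unreadable from compound 2 to compound 3 gives no further guidance. Compound 4 `Cc1ccc(C(C)C)cc1NC(=O)[C@@H]1CCCN1S(=O)(=O)c1cccc2cccnc12` differs by 5-isopropyl-2-methylphenyl in place of 2-ethylphenyl on an amide-type nitrogen. With the two substituted analogues both at the limit, compound 4 is expected to remain there, meaning a step that the limit leaves unreadable from compound 2 to compound 4. The estimate for compound 4 is 60000 nM, within 30000 nM to 120000 nM.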

Compound 4, half-maximal cytotoxic concentration: 9700 nM
Estimate against measurement, compound 4: 6.2-fold (0.79 log units) above, outside the stated range (below it).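

In this assay, among these compounds, this place on the amide-type nitrogen proves able to carry a real fall in the number: the change gives an at least 5.1-fold lower number from compound 2 to compound 4 (0.71 log units; beyond the scatter) and an at least 5.1-fold lower number from compound 3 to compound 4 (0.71 log units; beyond the scatter) and also a 3.7-fold lower number from compound 1 to compound 4 (0.56 log units; beyond the scatter) so 5-isopropyl-2-methylphenyl is the first group here to read lower than plain phenyl. The first two of these steps are floors only: the limit of > 50000 nM in this assay, at which 2 of the 4 values shown sit.

The compounds shown leave open whether the isopropyl or the methyl accounts for this fall, and whether a tert-butyl or a methoxy in place of the isopropyl would give the same result.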